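Adding a methoxy to the strongest of three compounds

The source may report more compounds than this note shows. Statements on the series, on what has been measured and on what is new or still open speak of the compounds shown alone.

compound 1 `COc1ccc(-c2c(-c3cc(OC)c(OC)c(OC)c3)noc2N)cc1OC`: 20600 nM
compound 2 `COc1ccc(-c2c(-c3cc(OC)c(OC)c(OC)c3)noc2NC(C)=O)cc1OC`: 17700 nM
compound 3 `COc1ccc(-c2c(-c3cc(OC)c(OC)c(OC)c3)noc2N(C(C)=O)C(C)=O)cc1`: 390 nM

In a functional assay on ECa-109 cells (Homo sapiens) for cytotoxicity, read by MTT assay, with a stated time of 48 h (a lower number here means a stronger inhibitor, a higher number a weaker inhibitor), compound 3 has the lowest of the three numbers, which makes it the strongest inhibitor so far, and its gaps to compound 1 and compound 2 lie beyond the scatter.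

Compound 4 `COc1ccc(-c2c(-c3cc(OC)c(OC)c(OC)c3)noc2N(C(C)=O)C(C)=O)cc1OC` is compound 3 with one change: methoxy in place of hydrogen on an aromatic carbon. Methoxy stands in place of hydrogen on an aromatic carbon, so 4-methoxyphenyl becomes 3,4-dimethoxyphenyl. The rest of compound 3 stays the same.

Within the data shown here, no measured step isolates this change. Among the measured compounds shown here, the only step available is a 1.2-fold lower number from compound 1 to compound 2 (0.07 log units; within the scatter), and it concerns another place, acetyl in place of hydrogen on a nitrogen. The 3,4-dimethoxyphenyl group already occurs in compound 1, at 20600 nM, and in compound 2, at 17700 nM. Both also differ from compound 3 on the nitrogen, so the data cannot show which difference goes with the lower number of compound 3.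

A move toward a higher number is expected, but its size is uncertain, and the estimate is a 3.8-fold higher number from compound 3 to compound 4 (0.59 log units; beyond the scatter). For compound 4 the expected value is 1500 nM, with an estimated range from 250 nM to 12000 nM.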

Compound 4, half-maximal inhibitory concentration: > 50000 nM
Compound 4: no number, only a limit (the forecaster's own chance of this, stated with the estimate: 5%); middle value at least 33-fold (1.52 log units) from the limit.
By their numbers in this assay, from the lowest: compound 3; then compounds 2 and 1 (each within the scatter of the next). At a limit, above all of these: compound 4.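

Compound 4 has no number in this assay, only a limit: the limit of > 50000 nM in this assay, at which 1 of the 4 values shown sits. Among these compounds, this gives the first direct reading of the change: with the diacetylamino group in place, a methoxy ortho to a methoxy group on the aromatic ring produces an at least 120-fold higher number from compound 3 to compound 4 (2.10 log units; beyond the scatter), so this position is far from indifferent to what it carries. The nitrogen also matters once the 3,4-dimethoxyphenyl group is present, with an at least 2.8-fold higher number from compound 2 to compound 4 (0.45 log units; beyond the scatter) and an at least 2.4-fold higher number from compound 1 to compound 4 (0.38 log units; beyond the scatter), so among these compounds the diacetylamino group does not go with a low number on its own, but only alongside the 4-methoxyphenyl group of compound 3.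

The compounds shown leave open whether any group at this place has the same effect or whether it is specific to methoxy, which a fluorine, a methyl or a hydroxyl there would help to settle. They also leave open how the amino and acetylamino forms behave with the 4-methoxyphenyl group, the comparison that would show whether the two places depend on each other.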